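Removing the fluorine from the biaryl group of compound 3

The compounds below may be only part of what the source reports. "The series", "measured", "known", "first", "only" and "open" are said of these compounds alone.

Measured compounds:
- compound 1, `Cc1cc(-c2cc(Cl)cc(C)c2/C=C/[C@@H]2C[C@@H](O)CC(=O)O2)ccc1F`: 6 nM
- compound 2, `O=C1C[C@H](O)CC(CCc2c(Cl)cc(Cl)cc2-c2ccccc2)O1`: 100 nM
- compound 3, `Cc1cc(-c2cc(Cl)cc(Cl)c2/C=C/[C@@H]2C[C@@H](O)CC(=O)O2)ccc1F`: 29 nM

Of the compounds shown here, three have been measured in an assay for inhibition of 3-hydroxy-3-methylglutaryl-coenzyme A reductase (Rattus norvegicus); on this read-out lower numbers stand for stronger inhibition and higher numbers for weaker inhibition. Compound 3 sits second highest of the three numbers: in this assay compound 3 gives 29 nM, while compound 1 gives 6 nM and compound 2 gives 100 nM.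

Going by the values given here, the only single-point step among the measured compounds is a 4.8-fold higher number from compound 1 to compound 3 (0.68 log units; beyond the scatter), which concerns a different part of the molecule than the change now in question. Compound 4, `Cc1ccc(-c2cc(Cl)cc(Cl)c2/C=C/[C@@H]2C[C@@H](O)CC(=O)O2)cc1`, differs from compound 3 by 4-methylphenyl in place of 4-fluoro-3-methylphenyl on an aromatic carbon. Among the compounds with values here, no measured pair isolates this change. Compound 2, which carries an unsubstituted phenyl group on a different core, gives 100 nM, a higher number than compound 3, but that comparison mixes several changes at once. Within the data shown here, with no direct precedent, the expectation for compound 4 is a step of a 1.4-fold higher number from compound 3 to compound 4 (0.14 log units; within the scatter), at most a small weakening that may stay within the scatter. Compound 4 is therefore estimated at 40 nM in this assay, with a range from 15 nM to 120 nM.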

Compound 4, half-maximal inhibitory concentration: 190 nM
Beside the measured number, compound 4's estimate is 4.8-fold (0.68 log units) below it; the whole stated range lies below it.
By their numbers in this assay, from the lowest: compound 1; then compound 3; then compounds 2 and 4 (each within the scatter of the next).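

In this assay, going by these compounds alone, exchanging 4-fluoro-3-methylphenyl for 4-methylphenyl gives a 6.6-fold higher number from compound 3 to compound 4 (0.82 log units; beyond the scatter), so this aromatic group is not a tolerant spot where small edits pass unnoticed, a point the earlier compounds could not show because none of them isolated a change here. The edit looks small on paper, going from 8 heavy atoms to 7 with the same carbon ring and no hydrogen-bond donors or acceptors on either side, yet the step lies clearly beyond the scatter. It is also more than the loss of a fluorine, since the names show that the methyl moves from the 3 position to the 4 position, where the fluoro group stood, and no measurement shown here explains why the number rises.

Going by these compounds, what stays open is whether the loss of the fluoro group or the new place of the methyl accounts for the step, as the two happen together in this one pair. A 4-fluorophenyl or a 3-methylphenyl group on the same aromatic carbon of the shared core would pull these two changes apart.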